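This account rests on a few compounds, and the source may have more. Where it says the series, first, only, none or still open, it means among the compounds named here.

Measured compounds:
Compound 1, `C[C@H]1CC[C@@H]2[C@@H](OC(=O)[C@]23CC(c2c(Cl)cccc2Cl)=NO3)[C@]2(C)C(=O)C=C[C@@]12O`, in a functional assay on PC-3 cells (Homo sapiens) for cytotoxicity, read by sulforhodamine B assay, with a stated time of 48 h (a higher number here means a weaker inhibitor, a lower number a stronger inhibitor), gives 56000 nM.
Compound 2, `C[C@H]1CC[C@@H]2[C@@H](OC(=O)[C@]23CC(c2ccccc2[N+](=O)[O-])=NO3)[C@]2(C)C(=O)C=C[C@@]12O`, in this assay gives 37000 nM.
Compound 3, `C[C@H]1CC[C@@H]2[C@@H](OC(=O)[C@]23CC(c2ccc([N+](=O)[O-])cc2)=NO3)[C@]2(C)C(=O)C=C[C@@]12O`, in this assay gives 12000 nM.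

Compound 2 stands second highest of the three numbers. Its nearest neighbour is compound 1, a step of a 1.5-fold lower number from compound 1 to compound 2 (0.18 log units; within the scatter) that lies within the scatter; its furthest is compound 3, reached by a 3.1-fold lower number from compound 2 to compound 3 (0.49 log units; beyond the scatter), a modest step beyond the scatter. The larger step of a 4.7-fold lower number from compound 1 to compound 3 (0.67 log units; beyond the scatter) points the same way.

Compound 4, `C[C@H]1CC[C@@H]2[C@@H](OC(=O)[C@]23CC(c2ccc(C#N)cc2)=NO3)[C@]2(C)C(=O)C=C[C@@]12O`, has not yet been measured. It differs from compound 2 as follows: 4-cyanophenyl in place of 2-nitrophenyl on a carbon with a double bond to nitrogen.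

Going by the values given here, only one measured step bears directly on this change, the one from compound 2 to compound 3, in which a 4-nitrophenyl replaced the 2-nitrophenyl and gave a 3.1-fold lower number from compound 2 to compound 3 (0.49 log units; beyond the scatter). Among the compounds with values here, no measured pair compares a 4-cyanophenyl with a 4-nitrophenyl, so the size of that part of the change is unknown. The account therefore expects compound 4 to move in the same direction as compound 3, by a modest step, with wide uncertainty.

The estimated value for compound 4 in this assay is 15000 nM, with a range from 6000 nM to 40000 nM. This corresponds to an expected step of a 2.5-fold lower number from compound 2 to compound 4 (0.39 log units; beyond the scatter).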

Compound 4, half-maximal inhibitory concentration: 32000 nM
For compound 4 the middle estimate is 2.1-fold (0.33 log units) below the measured one; the range from low to high includes it.
By their numbers in this assay, from the lowest: compound 3; then compounds 4, 2 and 1 (each within the scatter of the next).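

In this assay, going by these compounds alone, the exchange of nitro for cyano on the same aromatic carbon gives a 2.7-fold higher number from compound 3 to compound 4 (0.43 log units; beyond the scatter) and so shows what no earlier pair could: the lower number of the 4-nitrophenyl does not carry over to another group placed on that aromatic carbon. The 4-cyanophenyl does not separate from the 2-nitrophenyl, with a 1.2-fold lower number from compound 2 to compound 4 (0.06 log units; within the scatter) as its step, or from the 2,6-dichlorophenyl, with a 1.8-fold lower number from compound 1 to compound 4 (0.24 log units; within the scatter) as its step. Compound 3 alone now stands apart from the other three, so at this place on the carbon with a double bond to nitrogen the lower number goes with the 4-nitrophenyl in particular, and nothing shown here offers a reason for the difference between the nitro and the cyano group.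

As far as these compounds go, whether an amine, a carboxylic acid or a methoxy group on that same aromatic carbon would stand with the nitro group or with the cyano group remains open. Also open, from the compounds shown here alone, is whether an unsubstituted phenyl would stand apart from any of these four compounds, and so whether the nitro group lowers the number or the other groups raise it.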